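The compounds below may be only part of what the source reports. "The series", "measured", "known", "first", "only" and "open" are said of these compounds alone.

Three compounds built on one shared core were measured in a functional assay on SGC-7901 cells (Homo sapiens) for antiproliferative activity, read by MTT assay, with a stated time of 72 h; a lower number here means a stronger inhibitor, a higher number a weaker inhibitor. Compound 1 `COc1cc(-c2ccc3ncn(-c4cc(OC)c(OC)c(OC)c4)c3c2)cc(OC)c1OC` gives only > 10000 nM, which is the limit of > 10000 nM in this assay, at which 1 of the 3 values shown sits. Compound 2 `COc1cccc(-c2ccc3ncn(-c4cc(OC)c(OC)c(OC)c4)c3c2)c1` gives 3310 nM in this assay, and compound 3 `COc1ccc(-c2ccc3ncn(-c4cc(OC)c(OC)c(OC)c4)c3c2)cc1` gives 82 nM. The step of a 40-fold lower number from compound 2 to compound 3 (1.61 log units; beyond the scatter) is large, so compound 3 stands lowest of the two numbers, with compound 2 its nearest neighbour. Compound 4 `COc1cc(-n2cnc3ccc(-c4cccc(C)c4)cc32)cc(OC)c1OC` carries 3-methylphenyl in place of 4-methoxyphenyl on an aromatic carbon. Among the compounds with values here, the one measured step that bears on this, a 40-fold lower number from compound 2 to compound 3 (1.61 log units; beyond the scatter), shows how strongly this assay responds to which of these two phenyl groups is present, and compound 4 returns to a 3-substituted phenyl as in compound 2. The number for compound 4 is therefore expected to rise, by roughly an 18-fold higher number from compound 3 to compound 4 (1.26 log units; beyond the scatter), though methyl and methoxy are not the same group. Compound 4 is estimated at 1500 nM, between 300 nM and 6000 nM.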

Compound 4, half-maximal inhibitory concentration: 1240 nM
The estimate for compound 4 lay 1.2-fold (0.08 log units) above the measured number; measured number inside the range.
By their numbers in this assay, from the lowest: compound 3; then compound 4; then compound 2. At a limit, above all of these: compound 1.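

In this assay the swap of 4-methoxyphenyl for 3-methylphenyl gives a 15-fold higher number from compound 3 to compound 4 (1.18 log units; beyond the scatter) and so costs nearly as much as the swap to 3-methoxyphenyl did. Within the 3-substituted phenyl groups, methyl in place of methoxy gives only a 2.7-fold lower number from compound 2 to compound 4 (0.43 log units; beyond the scatter) as a modest step, so compounds 2 and 4 both remain well above compound 3. Nothing shown here gives a reason for either step.

As far as these compounds go, whether a 4-methylphenyl group would hold the low number of compound 3 stays open. So does how an amine or a hydroxyl group would read on this phenyl ring.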